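Trading a pyrrolidinyl ether for a hydroxypropyl chain

A few compounds are considered here, and "the series" means these few. Any claim that something is new, unique, unknown or untested is made for them only; others in the source may bear on it.

Measured compounds in an assay on isolated protein for inhibition of Rho-associated protein kinase 2 (Homo sapiens), read by HTRF, with a stated time of 4 h; a lower number here means a stronger inhibitor, a higher number a weaker inhibitor:
compound 1, `COc1ccc2c(c1)C[C@@H](C(=O)Nc1ccc(-c3cn[nH]c3)cc1O[C@@H]1CCN(C)C1)CO2`: 14 nM
compound 2, `COc1ccc2c(c1)C[C@H](C(=O)Nc1ccc(-c3cn[nH]c3)cc1O[C@H]1CCN(C)C1)CO2`: a limit of the assay, < 1 nM
compound 3, `COc1ccc2c(c1)C[C@@H](C(=O)Nc1ccc(-c3cn[nH]c3)cc1O[C@H]1CCN(C)C1)CO2`: 34 nM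

Compound 3 gives the highest of the two numbers shown, with compound 1 nearest, a 2.4-fold higher number from compound 1 to compound 3 (0.39 log units; beyond the scatter). All three share one set of atoms and bonds; the steps among them, an at least 14-fold lower number from compound 1 to compound 2 (1.14 log units; beyond the scatter) and an at least 34-fold higher number from compound 2 to compound 3 (1.53 log units; beyond the scatter), turn only on configuration as drawn, as the fact that compounds 1 and 2 differ only in the configuration as drawn, the fact that compounds 1 and 3 differ only in the configuration as drawn and the fact that compounds 2 and 3 differ only in the configuration as drawn state.

Compound 4, `COc1ccc2c(c1)C[C@@H](C(=O)Nc1ccc(-c3cn[nH]c3)cc1OCCCO)CO2`, differs from compound 3 by 3-hydroxypropyl in place of 1-methylpyrrolidin-3-yl on an oxygen on an aromatic ring. Going by the values given here, no measured step alters atoms or bonds, so none bears on this change directly. Compound 3 carries the configuration on its saturated ring that the measured steps disfavour, and the entering chain has no stereocentre. Compound 4 is therefore expected to give 60 nM, between 12 nM and 400 nM, a step of a 1.8-fold higher number from compound 3 to compound 4 (0.25 log units; within the scatter) that is an estimate only.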

Compound 4, half-maximal inhibitory concentration: 35 nM
For compound 4 the middle estimate is 1.7-fold (0.23 log units) above the measured one, within the range that was stated.
By their numbers in this assay, from the lowest: compound 1; then compounds 3 and 4 (each within the scatter of the next). At a limit, below all of these: compound 2.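

In this assay, going by these compounds alone, the earlier compounds varied only in configuration, whereas here the 1-methylpyrrolidin-3-yl group itself leaves, and its ring and stereocentre turn out not to be needed on this oxygen: the change gives a 1.0-fold higher number from compound 3 to compound 4 (0.01 log units; within the scatter) and no separation from compound 3. Set against the other pyrrolidine configuration, it gives a 2.5-fold higher number from compound 1 to compound 4 (0.40 log units; beyond the scatter) as a modest difference. Nothing shown gives a reason for either result.

Open, going by these compounds, is whether 3-hydroxypropyl would serve equally on the configuration of compound 2, whose < 1 nM is a limit of the assay. Also open, on these data alone, is how a longer chain, or an amine or a carboxylic acid at the chain's end, would read.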